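The compounds below may be only part of what the source reports. "The series", "measured", "known", "first", "only" and "open" are said of these compounds alone.

Values in an ADME assay on microsomes from liver (Homo sapiens) for metabolic stability, read by LC-MS, tested at 1 uM (a higher number here means faster removal of the compound, a lower number slower removal), as measured so far:
compound 1 `NCCOc1ccc([C@H]2CC[C@]3(CC2)OOC2(O3)C3CC4CC(C3)CC2C4)cc1` gives < 7 mL.min-1.g-1 as a limit
compound 2 `c1cc([C@H]2CC[C@]3(CC2)OOC2(O3)C3CC4CC(C3)CC2C4)ccc1OCCC1CCNCC1` gives < 7 mL.min-1.g-1 as a limit

Compound 2 stands at < 7 mL.min-1.g-1 as a limit of the assay and not a number. Within the data shown here, the series so far shows the limit of < 7 mL.min-1.g-1 in this assay, at which 2 of the 2 values shown sit, and nothing finer. Compound 3 `NC1CCN(S(=O)(=O)c2ccc([C@H]3CC[C@]4(CC3)OOC3(O4)C4CC5CC(C4)CC3C5)cc2)CC1` carries (4-aminopiperidin-1-yl)sulfonyl in place of 2-(piperidin-4-yl)ethoxy on an aromatic carbon, para to a large group ((4-aminopiperidin-1-yl)sulfonyl in place of 2-(piperidin-4-yl)ethoxy on an aromatic carbon). Among the measured compounds shown here, the only measured step is a step that the two limits leave unreadable from compound 1 to compound 2 and it concerns another change, so it offers no size to carry over. In this assay, for the measured compounds named here, no step of definite size or direction is expected, and the estimated outcome is a step that the limit leaves unreadable from compound 2 to compound 3 for this change. For compound 3 the expected value is 6 mL.min-1.g-1 with an estimated range from 3 mL.min-1.g-1 to 14 mL.min-1.g-1 in this series.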

Compound 3, intrinsic clearance in microsomes: < 7 mL.min-1.g-1
Compound 3: a limit, no number; the forecaster's own chance of this, stated with the estimate: 70%; the middle value does not contradict the limit.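

In this assay compound 3 gives < 7 mL.min-1.g-1, a limit of the assay and not a number. Among these compounds, no step among compound 1, compound 2 and compound 3 can be read. The compounds shown leave open whether these side-group exchanges on the shared core change intrinsic clearance in microsomes at all.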